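Side-chain change from compound 3 to compound 4

The compounds below may be only part of what the source reports. "The series", "measured", "known", "first", "only" and "open" are said of these compounds alone.

- compound 1 `CNC(=O)/C=C/c1ccncc1-c1ccc2ccccc2c1` gives 8680 nM
- compound 2 `CCOC(=O)/C=C/c1ccncc1-c1ccc2ccccc2c1` gives 8090 nM
- compound 3 `O=C(O)/C=C/c1ccncc1-c1ccc2ccccc2c1` gives > 10000 nM as a limit

In a functional assay on MDA-MB-231 cells (Homo sapiens) for inhibition, read by sulforhodamine B assay, with a stated time of 72 h (a higher number here means a weaker inhibitor of growth, a lower number a stronger inhibitor of growth), compound 1 and compound 2 lie within the scatter of each other (a 1.1-fold lower number from compound 1 to compound 2 (0.03 log units; within the scatter)). Compound 3 stands only at a limit of the assay (> 10000 nM) and has no number.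

Compound 4 `CNC(=O)CCc1ccncc1-c1ccc2ccccc2c1` is not yet measured. It carries 2-(methylcarbamoyl)ethyl in place of 2-carboxyethenyl on an aromatic carbon.

Among the compounds with values here, the steps that bear on this change are those on the carbonyl carbon (an at least 1.1-fold higher number from compound 1 to compound 3 (0.06 log units; that floor lies within the scatter) and an at least 1.2-fold higher number from compound 2 to compound 3 (0.09 log units; that floor lies within the scatter)). Both are floors only, and each floor lies within the scatter. Compound 4 shares the methylamino on a carbonyl carbon with compound 1 (8680 nM), which makes that value the closest anchor. Within the data shown here, no measured compound carries the 2-(methylcarbamoyl)ethyl group, so the rest of the change has no measured step.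

No step beyond the scatter is expected in this assay, and the expected step is small (an at least 1.1-fold lower number from compound 3 to compound 4 (0.04 log units; that floor lies within the scatter)). Compound 4 is estimated at 9000 nM (range 4500 nM to 18000 nM).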

Compound 4, concentration for 50% growth inhibition: 8980 nM
The estimate for compound 4 lay 1.0-fold (0.00 log units) above the measured number; measured number inside the range.
By their numbers in this assay, from the lowest: compounds 2, 1 and 4 (each within the scatter of the next). At a limit, above all of these: compound 3.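

In this assay, the side-chain double bond at this position can be removed with the methyl amide kept: the result is a 1.0-fold higher number from compound 1 to compound 4 (0.01 log units; within the scatter). Changing the ester side chain to the saturated amide side chain gives a 1.1-fold higher number from compound 2 to compound 4 (0.05 log units; within the scatter), so neither step moves the number beyond the scatter. The comparison with the acid gives only a floor, an at least 1.1-fold lower number from compound 3 to compound 4 (0.04 log units; that floor lies within the scatter), and compound 3 has a limit rather than a number: the limit of > 10000 nM in this assay, at which 1 of the 4 values shown sits.

With no step beyond the scatter, the compounds shown do not identify any feature of this side chain that changes growth inhibition in this assay. From the compounds shown here alone, it remains open whether an amine or a longer chain at this position, or a saturated chain ending in an ester or a carboxylic acid, would give a step beyond the scatter.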